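Phenyl in Place of Allyl: Expected Paw Edema Inhibition

The source may report more compounds than this note shows. Statements on the series, on what has been measured and on what is new or still open speak of the compounds shown alone.

Compound 1, `C=CCn1c(SCC(=O)c2ccccc2)nnc1-c1ccc(OC)cc1`: 49%
Compound 2, `COc1ccc(-c2nnc(SCC(=O)c3ccccc3)n2-c2ccccc2)cc1`: 52%
Compound 3, `C=CCn1c(SCC(=O)c2ccccc2)nnc1-c1cc(OC)c(OC)c(OC)c1`: 49%

In a functional assay on the whole organism (strain albino) for inhibition, with Rattus norvegicus as the target, read by paw edema, with a stated time of 1 h, at a dose of 0.28 mmol/kg by the oral route (on this read-out higher numbers stand for more inhibition at the one dose given (going by the name of the read-out) and lower numbers for less inhibition), compound 1 gives 49%, compound 2 gives 52% and compound 3 gives 49%. The change from compound 1 to compound 2 is phenyl in place of allyl on an aromatic nitrogen, and it made a step of a number 3 percentage points higher from compound 1 to compound 2 (within the scatter). Compound 3 and compound 1 differ in their cores; that difference is not broken down here. Compound 4, `COc1cc(-c2nnc(SCC(=O)c3ccccc3)n2-c2ccccc2)cc(OC)c1OC`, is not yet measured in this assay. Its change from compound 3 is phenyl in place of allyl on an aromatic nitrogen, the same kind of change as from compound 1 to compound 2, though the place differs: in one case the ring atom next to it bears a 4-methoxyphenyl group, in the other a (benzoylmethyl)sulfanyl group. Because the earlier step was a number 3 percentage points higher from compound 1 to compound 2 (within the scatter), the step from compound 3 to compound 4 is expected to be a number 3 percentage points higher from compound 3 to compound 4 (within the scatter), with the same scatter. For compound 4 the estimate is 52%, between 40% and 64%.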

Compound 4, a percentage reported as inhibition, in the whole organism at one dose (the size of the read-out at that dose, not a potency): 44%
Compound 4: the middle estimate sits 8 percentage points above what was measured, and the stated range covers the measured number.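

In this assay, phenyl in place of allyl on an aromatic nitrogen gave a number 5 percentage points lower from compound 3 to compound 4 (within the scatter). Set beside the earlier step, the two cores do not differ in their response to this change: the same change on two cores in this assay, a number 3 percentage points higher (within the scatter) from compound 1 to compound 2 and a number 5 percentage points lower (within the scatter) from compound 3 to compound 4, 8 percentage points apart, within the scatter of two such steps. This shows that, at this one dose, the change carried across these two cores without a detectable difference, but it does not show that the change has no effect, nor that it would behave the same way on any other core.

The compounds shown leave open whether a different group on that aromatic nitrogen, such as a longer chain or an amine, would move the inhibition beyond the scatter. They also leave open what a carboxylic acid in place of the methoxy groups would do.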